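Changing the amine side group of compound 1

A few compounds are considered here, and "the series" means these few. Any claim that something is new, unique, unknown or untested is made for them only; others in the source may bear on it.

Compound 1 `O=C1NC(=O)c2ccc(I)cc2/C1=C/Nc1ccc(CN2CCCCC2)cc1`: 1000 nM
Compound 2 `O=C1NC(=O)c2ccc(-c3ccoc3)cc2/C1=C/Nc1ccc(CN2CCCCC2)cc1`: 1100 nM

In a functional assay on MCF7 cells (Homo sapiens) for antiproliferative activity, read by sulforhodamine B assay (a higher number here means a weaker inhibitor, a lower number a stronger inhibitor), compound 1 gives 1000 nM, level with compound 2 at 1100 nM. Compound 3 `CN1CC2CC1CN2c1ccc(N/C=C2\C(=O)NC(=O)c3ccc(I)cc32)cc1` keeps the iodo group of compound 1 and changes another group: a group of 8 heavy atoms (6 carbon, 2 nitrogen; 2 five-membered non-aromatic rings with 1 hetero atom each) in place of a group of 7 heavy atoms (6 carbon, 1 nitrogen; one six-membered non-aromatic ring with 1 hetero atom), on an aromatic carbon. Among the compounds with values here, the one measured step, a 1.1-fold higher number from compound 1 to compound 2 (0.04 log units; within the scatter), replaced the iodo group, so it offers only weak guidance. Within the data shown here, no measured step touches the group changed here. In this assay no step beyond the scatter is expected in either direction, although the uncertainty is wide. The expected step is a 1.3-fold lower number from compound 1 to compound 3 (0.10 log units; within the scatter). For compound 3 the estimated value is 800 nM, with an expected range from 200 nM to 3000 nM.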

Compound 3, half-maximal inhibitory concentration: 2600 nM
For compound 3 the middle estimate is 3.3-fold (0.51 log units) below the measured one; the measured number falls inside the stated range.
By their numbers in this assay, from the lowest: compounds 1 and 2 (each within the scatter of the next); then compound 3.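

Within the data shown here, this is the first measured change at the amine side group, and it gives a 2.6-fold higher number from compound 1 to compound 3 (0.41 log units; beyond the scatter) in this assay, a modest loss of strength. So, unlike the swap of iodo for furan-3-yl, which stayed within the scatter, replacing (piperidin-1-yl)methyl with this two-ring group moves the number beyond the scatter. Nothing available explains this shift.

From the compounds shown here alone, whether a morpholin-4-ylmethyl or a dimethylaminomethyl group at this place would behave like compound 1 or compound 3 remains open. Also open, going by these compounds, is whether the new two-ring group would give a similar step with furan-3-yl in place of iodo.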